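The source may hold more compounds than are shown below. What is called first, only, known or untested is meant among the compounds shown, and "the series" means these compounds.

Compound 1 `Cc1cc(NC(=O)Nc2ccc(F)cc2)c2ccccc2n1` gives in an ADME assay on HEK293 cells (Homo sapiens) for cytotoxicity, with a stated time of 72 h (on this read-out lower numbers stand for an effect already at smaller amounts and higher numbers for an effect only at larger amounts of compound), only a limit, > 25000 nM. Compound 2 `CSc1ccc(NC(=O)Nc2cc(C)nc3ccccc23)cc1` gives in this assay 24000 nM. Compound 3 `Cc1cc(NC(=O)Nc2ccc(Cl)cc2)c2ccccc2n1` gives in this assay only a limit, > 25000 nM.

Compound 3 thus stands at the limit of > 25000 nM in this assay, at which 2 of the 3 values shown sit. Compound 4 `Cc1cc(NC(=O)Nc2ccc(OC(F)(F)F)cc2)c2ccccc2n1` differs from compound 3 by trifluoromethoxy in place of chloro on an aromatic carbon. For the measured compounds named here, no measured step exchanges chloro for trifluoromethoxy, so the steps that bear on it are those ending at compound 3: a step that the two limits leave unreadable from compound 1 to compound 3 and an at least 1.0-fold higher number from compound 2 to compound 3 (0.01 log units; that floor lies within the scatter). Neither shows anything beyond the scatter, and replacing fluoro by methylsulfanyl or chloro on that ring left all three compounds close together. Compound 4 is therefore expected at 25000 nM, between 12000 nM and 50000 nM, and most likely again reported as a limit. That estimate means an expected a number no higher from compound 3 to compound 4 (the limit leaves the size open).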

Compound 4, half-maximal effective concentration: 14000 nM
Beside the measured number, compound 4's estimate is 1.8-fold (0.25 log units) above it; the range from low to high includes it.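

Trifluoromethoxy, para to a large group, yields a measured number in this assay, where chloro and fluoro yielded only limits. The change gives an at least 1.7-fold lower number from compound 3 to compound 4 (0.25 log units; that floor lies within the scatter) and an at least 1.7-fold lower number from compound 1 to compound 4 (0.25 log units; that floor lies within the scatter), both only floors, and a 1.7-fold lower number from compound 2 to compound 4 (0.23 log units; within the scatter), so no shift beyond the scatter is shown. Compound 1 and compound 3 each remain at a limit of the assay, which keeps the full size of their steps open: the limit of > 25000 nM in this assay, at which 2 of the 4 values shown sit.

Going by these compounds, whether an amine or a carboxylic acid at this position would move the number beyond the scatter remains open.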